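A few compounds are considered here, and "the series" means these few. Any claim that something is new, unique, unknown or untested is made for them only; others in the source may bear on it.

Measured so far in a functional assay on L1210 cells (Mus musculus) for inhibition; on this read-out lower numbers stand for stronger inhibition and higher numbers for weaker inhibition:
Compound 1 `C#CCOC(=O)c1ccc2[nH]c(NC(=O)OC)nc2c1` gives 10000 nM.
Compound 2 `COC(=O)Nc1nc2cc(C(=O)OC(C)C)ccc2[nH]1` gives 700 nM.
Compound 3 `C=CCOC(=O)c1ccc2[nH]c(NC(=O)OC)nc2c1` gives only a limit of the assay, > 10000 nM.

Compound 1 stands highest of the two numbers given; its nearest neighbour is compound 2, with a 14-fold lower number from compound 1 to compound 2 (1.15 log units; beyond the scatter). The third value is a limit and so sits apart from the numbers (the limit of > 10000 nM in this assay, at which 1 of the 3 values shown sits).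

Compound 4 `COC(=O)Nc1nc2cc(C(=O)OCC3CC3)ccc2[nH]1` is not yet measured. It differs from compound 1 in one place: cyclopropyl in place of ethynyl on a saturated chain carbon bound to an oxygen next to a carbonyl group. Among the measured compounds shown here, two measured steps bear on this. The step of a 14-fold lower number from compound 1 to compound 2 (1.15 log units; beyond the scatter) shows that a saturated, branched group on the oxygen next to the carbonyl group lowers the number strongly. The step of a number no lower from compound 1 to compound 3 (the limit leaves the size open) shows that exchanging the ethynyl for another unsaturated group gives no lower number. Cyclopropyl is saturated and branched, more like isopropyl than like vinyl, so a lowering of the number is expected, though smaller than the isopropyl case since the chain is one carbon longer. For compound 4 the expected step is a 4.0-fold lower number from compound 1 to compound 4 (0.60 log units; beyond the scatter). Compound 4 is therefore estimated at 2500 nM, within a range from 600 nM to 10000 nM.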

Compound 4, half-maximal inhibitory concentration: 6900 nM
For compound 4 the middle estimate is 2.8-fold (0.44 log units) below the measured one; measured number inside the range.
By their numbers in this assay, from the lowest: compound 2; then compounds 4 and 1 (each within the scatter of the next).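

In this assay, cyclopropyl in place of ethynyl on a saturated chain carbon bound to an oxygen next to a carbonyl group gives a 1.4-fold lower number from compound 1 to compound 4 (0.16 log units; within the scatter) and so makes no clear difference; a saturated ring at this place is not enough for a low number. Cyclopropylmethyl in place of isopropyl gives a 9.9-fold higher number from compound 2 to compound 4 (0.99 log units; beyond the scatter) and shows that the low number of compound 2 does not extend to this other saturated group on the same oxygen. Cyclopropyl in place of vinyl gives an at least 1.4-fold lower number from compound 3 to compound 4 (0.16 log units; that floor lies within the scatter) and fixes no order between the two, since this step starts from a limit: the limit of > 10000 nM in this assay, at which 1 of the 4 values shown sits.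

Still open, going by these compounds, is how a smaller ethyl, a bulkier tert-butyl or a longer chain would fare on this oxygen. Also open, on these data alone, is whether a cyclopropyl or cyclopentyl ring, set on the oxygen without the extra chain carbon, would match isopropyl.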